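Trifluoromethyl to Cyano: the Next Step from Compound 3

The source may hold more compounds than are shown below. What is called first, only, known or untested is meant among the compounds shown, and "the series" means these compounds.

Three compounds have been measured in an assay on Sf9 cells for inhibition of sphingosine-1-phosphate lyase 1 (Homo sapiens), with a stated time of 1 h; a lower number here means a stronger inhibitor, a higher number a weaker inhibitor:
compound 1 `C[C@@H]1CN(c2nnc(-c3ccccc3)c3ccccc23)CCN1c1ccc(C#N)cn1` gives > 30000 nM;
compound 2 `C[C@@H]1CN(c2nnc(Cc3ccccc3)c3cc(Cl)ccc23)CCN1c1ccc(C#N)cn1` gives 2300 nM;
compound 3 `C[C@@H]1CN(c2nnc(Cc3ccccc3)c3ccc(C(F)(F)F)cc23)CCN1c1ccc(C#N)cn1` gives 100 nM.

The value of compound 1 is a limit of this assay, not a number, as recorded by the limit of > 30000 nM in this assay, at which 1 of the 3 values shown sits. Among the two real numbers, compound 3 holds the lower one, and compound 2 sits well beyond the usual scatter higher. Compound 4 `C[C@@H]1CN(c2nnc(Cc3ccccc3)c3ccc(C#N)cc23)CCN1c1ccc(C#N)cn1` differs from compound 3 by cyano in place of trifluoromethyl on an aromatic carbon. For the measured compounds named here, no measured pair shows this change, so in this assay only a modest step toward a higher number, near the edge of the scatter, is expected: a 2.5-fold higher number from compound 3 to compound 4 (0.40 log units; beyond the scatter). Compound 4 is therefore estimated at 250 nM, likely between 60 nM and 1000 nM.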

Compound 4, half-maximal inhibitory concentration: 24 nM
Beside the measured number, compound 4's estimate is 10-fold (1.02 log units) above it; the measured number lies below the stated range.
By their numbers in this assay, from the lowest: compound 4; then compound 3; then compound 2. At a limit, above all of these: compound 1.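

On this aromatic carbon, cyano in place of trifluoromethyl gives a 4.2-fold lower number from compound 3 to compound 4 (0.62 log units; beyond the scatter) in this assay. For the compounds shown here, this is the first change at a single place that can be read, and it shows that the group with fewer heavy atoms, which also brings a hydrogen-bond acceptor, gives the lower number here. Nothing shown explains why this swap lowers the number.

This rests on a single pair of compounds. From the compounds shown here alone, how an amine, a carboxylic acid or a plain hydrogen on this same carbon would compare remains open.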